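Swapping a Double Bond for a Triple Bond

This account rests on a few compounds, and the source may have more. Where it says the series, first, only, none or still open, it means among the compounds named here.

Among the compounds with values here, in a physicochemical assay for lipophilicity (a higher number here means a more lipophilic compound, a lower number a more polar compound), compound 1 `C=CC(C)(C)OC[n+]1ccn(C)c1/C=N/O` gives -1.54, the lower of the two numbers measured so far. Within the data shown here, the only other measured compound, compound 2 `C=CC(CCC)OC[n+]1ccn(C)c1/C=N/O`, gives -0.87, which stands higher by more than the usual scatter of repeat measurements. Among the measured compounds shown here, no measured pair yet shows a change of the kind that comes next, so these two values offer only a rough frame.

Compound 3 `CC#CC(C)OC[n+]1ccn(C)c1/C=N/O` has not been measured. It keeps the shared core, but on an oxygen on a saturated carbon the 1,1-dimethylprop-2-en-1-yl group gives way to a group carrying a triple bond: a group of 5 heavy atoms (5 carbon; no ring) in place of a group of 5 heavy atoms (5 carbon; no ring), on an oxygen on a saturated carbon. The entering and leaving groups have the same count of heavy atoms, so the expectation stays close to compound 1 at -1.54. In this assay, no step beyond the scatter is expected, in either direction. The estimated step of a number 0.06 log units lower from compound 1 to compound 3 (within the scatter) is therefore small. For compound 3 the expected value is -1.6, with an estimated range from -2 to -1.2.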

Compound 3, distribution coefficient: -1.74
Beside the measured number, compound 3's estimate is 0.14 log units above it, within the range that was stated.
By their numbers in this assay, from the lowest: compounds 3 and 1 (each within the scatter of the next); then compound 2.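

In this assay, exchanging the 1,1-dimethylprop-2-en-1-yl group for a group with the same count of heavy atoms but a triple bond gives a number 0.20 log units lower from compound 1 to compound 3 (within the scatter). Within the data shown here, this is the first step that can be read at this position, on an oxygen on a saturated carbon, and repeat measurements could not tell it from no change at all. In this single pair, then, a double bond outside aromatic rings can give way to a triple bond, with no ring and no hydrogen-bond donors or acceptors in either group, and the read-out stays within the scatter; no measurement in hand offers an explanation for this result. What the compounds shown leave open is whether a group of a different make-up on this oxygen, such as an amine, a carboxylic acid or a longer chain, would give a step beyond the scatter. Also open, as far as these compounds go, is whether a triple bond in place of a double bond would give so small a step again in a different chain or on a different core.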